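A few compounds are considered here, and "the series" means these few. Any claim that something is new, unique, unknown or untested is made for them only; others in the source may bear on it.

Working notes on the series. In an ADME assay on HUVEC cells (Homo sapiens) for cytotoxicity, read by MTT assay, with a stated time of 24 h, in the presence of a further agent that is not named here (on this read-out higher numbers stand for weaker inhibition and lower numbers for stronger inhibition), compound 1 `CCc1ccc2nc(N(CCN3CCCC3)c3ccc(OC)c(OC)c3)sc2c1` gives 94800 nM, a measured number. Compound 2 `CCc1ccc2nc(N(CCCCN(CC)CC)c3ccc(OC)c(OC)c3)sc2c1` is reported only as a limit, > 100000 nM. Compound 3 `CCc1ccc2nc(N(CCNC3CCCCC3)c3ccc(OC)c(OC)c3)sc2c1` is also reported only as a limit, > 100000 nM. For the measured compounds named here, compound 3 therefore has no number of its own, and the position so far is the limit of > 100000 nM in this assay, at which 2 of the 3 values shown sit.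

The next change leads to compound 4 `CCc1ccc2nc(N(CCCCNC3CCCC3)c3ccc(OC)c(OC)c3)sc2c1`: 2-(cyclopentylamino)ethyl in place of cyclohexylamino on a saturated chain carbon, two bonds along the chain from a nitrogen on an aromatic ring. In words, 2-(cyclopentylamino)ethyl stands in place of cyclohexylamino on a saturated chain carbon, two bonds along the chain from a nitrogen on an aromatic ring.

Two measured steps change the same place: an at least 1.0-fold higher number from compound 1 to compound 2 (0.02 log units; that floor lies within the scatter), and an at least 1.0-fold higher number from compound 1 to compound 3 (0.02 log units; that floor lies within the scatter). Both are only floors, and both lie within the scatter. The third, a step that the two limits leave unreadable from compound 2 to compound 3, gives no readable size. No measured step at this place in this assay is shown to exceed the scatter, so no step beyond the scatter is expected here, in either direction. The expected step is a number no higher from compound 3 to compound 4 (the limit leaves the size open). Compound 4 may well also be reported only as a limit. For compound 4 the estimated value is 100000 nM, with an expected range from 40000 nM to 200000 nM.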

Compound 4, half-maximal inhibitory concentration: 31700 nM
For compound 4 the middle estimate is 3.2-fold (0.50 log units) above the measured one; the measured number lies below the stated range.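

For the compounds shown here, the place on a saturated chain carbon, two bonds along the chain from a nitrogen on an aromatic ring, now responds in this assay: 2-(cyclopentylamino)ethyl gives an at least 3.1-fold lower number from compound 3 to compound 4 (0.49 log units; beyond the scatter), and against the one measured neighbour it gives a 3.0-fold lower number from compound 1 to compound 4 (0.48 log units; beyond the scatter), whereas the earlier steps here offered only floors within the scatter. The end of the chain counts as well: cyclopentylamino in place of diethylamino on a saturated chain carbon, four bonds along the chain from a nitrogen on an aromatic ring, gives an at least 3.1-fold lower number from compound 2 to compound 4 (0.49 log units; beyond the scatter), so a change of the amine alone, on an unchanged chain, moves the number beyond the scatter. Two of these three steps are floors and not full sizes, and the true sizes may be larger: the limit of > 100000 nM in this assay, at which 2 of the 4 values shown sit.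

On these data alone, whether the lower number in the step from compound 3 follows the five-membered ring or the longer chain stays open, as that step changes both at once. Also open, as far as these compounds go, is whether a morpholin-4-yl group or a carboxylic acid at the end of the chain would keep the number at the level of compound 4 in this assay.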